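The source may hold more compounds than are shown below. What is called first, only, known or untested is meant among the compounds shown, and "the series" means these compounds.

In a functional assay on HepG2 cells (Homo sapiens) for inhibition, read by scintillation counting, with a stated time of 2 h (a lower number here means a stronger inhibitor, a higher number a weaker inhibitor), compound 1 `CC(=O)N1CCC(C(=O)N2CCC(N3CCN(C(=O)c4cc(-c5ccc(C)cc5)nc(-c5ccc6[nH]c(C)c(C)c6c5)c4)CC3)CC2)CC1` gives 294 nM as its result. Compound 2 `CCCCC(=O)N1CCC(N2CCN(C(=O)c3c(NC(=O)NCC)sc4ccccc34)CC2)CC1` has no place on that scale: its result reads "not determined" (no result reported) and gives no figure. Compound 3 `CCNC(=O)Nc1sc2ccccc2c1C(=O)N1CCN(C2CCN(C(=O)C3CCCCC3)CC2)CC1` is still unmeasured. The step cyclohexyl in place of butyl on a carbonyl carbon puts cyclohexyl in place of butyl on a carbonyl carbon. Among the compounds with values here, no measured pair shows what such a swap does, so no step beyond the usual scatter is expected in this assay, in either direction. Within the data shown here, the only guide is compound 1 at 294 nM as a rough reference, from a different structure. Compound 3 is therefore estimated at 250 nM with an expected range from 40 nM to 1500 nM as a wide span.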

Compound 3, half-maximal inhibitory concentration: 146 nM
Beside the measured number, compound 3's estimate is 1.7-fold (0.23 log units) above it, and the stated range covers the measured number.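

In this assay only compound 3 carries a number, so no step can be read from compound 2 to compound 3. From the compounds shown here alone, what cyclohexyl in place of butyl does to inhibition stays open, and no evidence bears on this result.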